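Moving from an Ester to a Methyl Amide

The compounds below may be only part of what the source reports. "The series", "measured", "known", "first", "only" and "open" are said of these compounds alone.

Measured in a functional assay on NTUB1 cells (Homo sapiens) for cytotoxicity, read by MTT assay, with a stated time of 72 h (a lower number here means a stronger inhibitor, a higher number a weaker inhibitor), so far:
Compound 1 `COc1ccc(OC)c(C(=O)/C=C/c2ccc(C(=O)OC(C)C)cc2)c1` gives 4420 nM
Compound 2 `COc1ccc(OC)c(C(=O)/C=C/c2ccc(C(=O)OCC=C(C)C)cc2)c1` gives 13400 nM

Compound 2 holds the higher of the two numbers. Compound 3 `CNC(=O)c1ccc(/C=C/C(=O)c2cc(OC)ccc2OC)cc1` differs from it by methylamino in place of (3-methylbut-2-en-1-yl)oxy on a carbonyl carbon, with methylamino in place of (3-methylbut-2-en-1-yl)oxy on a carbonyl carbon. Among the measured compounds shown here, the only measured step that bears on this is a 3.0-fold higher number from compound 1 to compound 2 (0.48 log units; beyond the scatter), a modest one, and no measured compound carries methylamino. A step of similar size towards a lower number is therefore expected in this assay, though with wide uncertainty. The expected change is a 2.2-fold lower number from compound 2 to compound 3 (0.35 log units; beyond the scatter). For compound 3 the estimated value is 6000 nM, with an expected range of 2000 nM to 18000 nM.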

Compound 3, half-maximal inhibitory concentration: 2200 nM
Compound 3: middle estimate off by 2.7-fold (0.44 log units), on the high side, within the range that was stated.
By their numbers in this assay, from the lowest: compounds 3 and 1 (each within the scatter of the next); then compound 2.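

In this assay, methylamino in place of (3-methylbut-2-en-1-yl)oxy on the carbonyl carbon gives a 6.1-fold lower number from compound 2 to compound 3 (0.78 log units; beyond the scatter), which shows that this position accepts an amide as well as an ester. Set against the isopropoxy ester, the same methylamino group gives a 2.0-fold lower number from compound 1 to compound 3 (0.30 log units; within the scatter), so these two compounds cannot be told apart here. Nothing available explains either step. On these data alone, it remains open how a carboxylic acid, a longer chain on the nitrogen or a dimethylamino group would compare at this carbonyl carbon, and whether the amide hydrogen matters.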